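Trifluoromethyl Steps on a Shared Core: Estimating Compound 4

A few compounds are considered here, and "the series" means these few. Any claim that something is new, unique, unknown or untested is made for them only; others in the source may bear on it.

Compound 1, `CC1=C(C(=O)OC(C(F)(F)F)C(F)(F)F)C(c2cccs2)NC(=O)N1`, gives 9% in an assay on cells for displacement of a labelled ligand from adenosine receptor A1 (Homo sapiens), read by radioligand binding, with a stated time of 60 min, tested at 1 uM; a higher number here means more inhibition at the concentration tested (going by the name of the read-out), a lower number less inhibition. Compound 2, `CC1=C(C(=O)OCC(F)(F)F)C(c2cccs2)NC(=O)N1`, gives 3% in this assay. Compound 3, `CC1=C(C(=O)OCC(F)(F)F)C(c2ccco2)NC(=O)N1`, gives 10% in this assay.

All three numbers are low, and no two of them lie apart by more than the usual scatter, so none of the three can be singled out as having the higher or the lower number. Compound 1 differs from compound 2 by trifluoromethyl in place of hydrogen on a saturated chain carbon bound to an oxygen next to a carbonyl group and a saturated chain carbon; this change made a step of a number 6 percentage points higher from compound 2 to compound 1 (within the scatter). Compound 3 differs from compound 2 in its core by furan-2-yl in place of thiophen-2-yl on a saturated ring carbon, a change that made a step of a number 7 percentage points higher from compound 2 to compound 3 (within the scatter). Compound 1 and compound 3 show numbers close to each other, within the scatter.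

Compound 4, `CC1=C(C(=O)OC(C(F)(F)F)C(F)(F)F)C(c2ccco2)NC(=O)N1`, has not yet been measured in this assay. It differs from compound 3 by trifluoromethyl in place of hydrogen on a saturated chain carbon bound to an oxygen next to a carbonyl group and a saturated chain carbon, and the place of this change is described in the same words as the place of the change from compound 2 to compound 1, so it is the same change made on the other core. Among the compounds with values here, only one earlier instance of this change exists, which is a thin basis. For compound 4 the step from compound 3 is expected to be about a number 5 percentage points higher from compound 3 to compound 4 (within the scatter), resting on the earlier step of a number 6 percentage points higher from compound 2 to compound 1 (within the scatter), which was itself within the scatter. Compound 4 is therefore estimated to give about 15% in this assay, with a range from 3% to 28% that reflects the scatter of single-concentration readings at this low level.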

Compound 4, a percentage reported as inhibition, at one concentration (the size of the read-out at that concentration, not a potency): 6%
Compound 4: the middle estimate sits 9 percentage points above what was measured; the measured number falls inside the stated range.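

On the furan-2-yl core, trifluoromethyl in place of hydrogen gave a number 4 percentage points lower from compound 3 to compound 4 (within the scatter), and furan-2-yl in place of thiophen-2-yl, on the core carrying the added trifluoromethyl, gave a number 3 percentage points lower from compound 1 to compound 4 (within the scatter). Carried from one core to the other, the trifluoromethyl change shows no difference that stands clear of the scatter, so nothing here indicates that it behaves differently on the two cores, yet the small steps at these low numbers do not show that it behaves alike either: the same change on two cores in this assay, a number 6 percentage points higher (within the scatter) from compound 2 to compound 1 and a number 4 percentage points lower (within the scatter) from compound 3 to compound 4, 10 percentage points apart, within the scatter of two such steps The exchange of furan-2-yl for thiophen-2-yl allows the same limited reading, neither a transfer nor a failure to transfer being shown: the same change on two cores in this assay, a number 7 percentage points higher (within the scatter) from compound 2 to compound 3 and a number 3 percentage points lower (within the scatter) from compound 1 to compound 4, 10 percentage points apart, within the scatter of two such steps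

The compounds shown hold only fluorinated chains on the oxygen next to the carbonyl group and only furan-2-yl or thiophen-2-yl on the saturated ring carbon, so they leave open what a longer unfluorinated chain at the first place or a phenyl group at the second would give in this assay. They also leave open how the trifluoromethyl change would read on a core whose number stands well clear of the scatter.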